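Propyl to 4-Hydroxyphenyl: an Expected Gain in Potency

The source may report more compounds than this note shows. Statements on the series, on what has been measured and on what is new or still open speak of the compounds shown alone.

Compound 1 `CCCCN1CCC(C(=O)Nc2cc(Cl)c(N)cc2OC)CC1` gives only a limit in a functional assay on the whole organism for antagonist activity, with Mus musculus as the target; a lower number here means that less compound is needed, a higher number that more compound is needed for the effect: > 10 mg/kg.
Compound 2 `COc1cc(N)c(Cl)cc1NC(=O)C1CCN(Cc2ccccc2Cl)CC1` also gives only a limit, namely > 4 mg/kg.
Compound 3 `COc1cc(N)c(Cl)cc1NC(=O)C1CCN(Cc2ccc(F)cc2)CC1` gives a true number, 0.6 mg/kg.

Compound 1 stands at the weak end of the three: its value is one of two limits here, the other being (the limit of > 4 mg/kg in this assay, at which 1 of the 3 values shown sits), while compound 3 alone gives a measured dose. The unmeasured compound 4 `COc1cc(N)c(Cl)cc1NC(=O)C1CCN(Cc2ccc(O)cc2)CC1` differs from compound 1 by 4-hydroxyphenyl in place of propyl on a saturated chain carbon bound to an amine nitrogen in a ring.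

For the measured compounds named here, two measured steps bear on this change. The closest is an at least 16-fold lower number from compound 1 to compound 3 (1.22 log units; beyond the scatter), where an aryl group with a substituent at the same ring position enters in place of propyl. The step that the two limits leave unreadable from compound 1 to compound 2 shows that an aryl group substituted elsewhere does not secure such a gain, and an at least 6.6-fold lower number from compound 2 to compound 3 (0.82 log units; beyond the scatter) confirms the spread between these two aryl patterns. Compound 4 carries its substituent where compound 3 does, so a large drop in dose is expected, though the hydroxyl in place of fluorine adds uncertainty. For compound 4 the expected step is an at least 10-fold lower number from compound 1 to compound 4 (1.00 log units; beyond the scatter). Compound 4 is therefore estimated at 1 mg/kg, with a range from 0.3 mg/kg to 4 mg/kg.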

Compound 4, dose for half-maximal effect: > 8 mg/kg
Compound 4 gave a limit, no number; the forecaster's own chance of this, stated with the estimate: 20%; middle value at least 8.0-fold (0.90 log units) away from the limit.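

In this assay, for the compounds shown here, hydroxy in place of fluoro on an aromatic carbon gives an at least 13-fold higher number from compound 3 to compound 4 (1.12 log units; beyond the scatter), the first step here in which the aryl substituent changes while its ring position stays the same. The earlier compounds had shown only that compound 2 and compound 3, with different substituents at different ring positions, lie apart, whereas this step shows that the substituent itself matters: the ring position shared with compound 3 does not secure a low dose, and neither does an aryl group in place of propyl alone. Compound 4 gives only a limit, which it does not share with any other compound shown, and its steps from compound 1 and from compound 2 join limit to limit and cannot be read: the limit of > 8 mg/kg in this assay, at which 1 of the 4 values shown sits.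

How far compound 4 lies from compound 3 has only a lower bound, and compound 3 remains the sole measured dose among the four compounds, so the series has no second number to set against it. From the compounds shown here alone, whether methoxy or an amine in place of fluoro on an aromatic carbon would keep the dose of compound 3 or lose it as hydroxy does stays open.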